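The source may report more compounds than this note shows. Statements on the series, on what has been measured and on what is new or still open speak of the compounds shown alone.

Measured so far:
- compound 1, `COc1cc(COC(c2ccc(OC)c(OC)c2OC)c2cccc3ccccc23)cc(OC)c1`
- compound 2, `COc1ccc(/C(=N/O)c2cccc3ccccc23)c(OC)c1OC`

In a functional assay on MDA-MB-231 cells (Homo sapiens) for inhibition, read by sulforhodamine B assay, with a stated time of 48 h (a higher number here means a weaker inhibitor, a lower number a stronger inhibitor), compound 1 gives only a limit, > 20000 nM, and no number. In this assay compound 2 gives 2500 nM. For the measured compounds named here, this is the only number the series shows; the other reading sits at the limit of > 20000 nM in this assay, at which 1 of the 2 values shown sits, so compound 2 cannot yet be placed against any measured neighbour, and no measured step exists between the two.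

Compound 3, `COc1ccc(/C(=N/OCC(=O)O)c2cccc3ccccc23)c(OC)c1OC`, is the next target. Its difference from compound 2 is carboxymethyl in place of hydrogen on an oxygen. Nothing measured here speaks to a change of this kind, so the expectation rests on compound 2 alone at 2500 nM. The expected step from compound 2 to compound 3 is a 3.2-fold higher number from compound 2 to compound 3 (0.51 log units; beyond the scatter), a loss beyond the scatter rather than a gain. On that basis the estimate for compound 3 in this assay is 8000 nM, expected to lie between 2000 nM and 30000 nM.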

Compound 3, half-maximal inhibitory concentration: > 20000 nM
Compound 3 was reported as a limit (the forecaster's own chance of this, stated with the estimate: 30%); middle value at least 2.5-fold (0.39 log units) from the limit.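

For the compounds shown here, this is the first measured step: with carboxymethyl in place of hydrogen on the oxygen bound to the double-bonded nitrogen, this assay shows an at least 8.0-fold higher number from compound 2 to compound 3 (0.90 log units; beyond the scatter). The hydrogen of compound 2 therefore cannot be exchanged freely at this position, and the hydroxy to carboxymethoxy change costs activity beyond the scatter. The size of that loss is only a bound, as compound 3 gives a limit and no number: the limit of > 20000 nM in this assay, at which 2 of the 3 values shown sit.

As far as these compounds go, whether the loss follows from the carboxyl end of the chain or from any substituent on this oxygen stays open. A methyl group, the methyl ester of the same chain or an aminoethyl chain at this position would help to separate those two readings.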